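The source may report more compounds than this note shows. Statements on the series, on what has been measured and on what is new or still open speak of the compounds shown alone.

Values in a functional assay on MCF7 cells (Homo sapiens) for inhibition, read by sulforhodamine B assay, with a stated time of 48 h (on this read-out higher numbers stand for weaker inhibition of growth and lower numbers for stronger inhibition of growth), for the measured compounds:
Compound 1 `O=C(CCl)NC(=O)Nc1cccc(OC2CCCC2)c1` gives 6200 nM
Compound 2 `O=C(CCl)NC(=O)Nc1cccc(OC2CCCCC2)c1` gives 6300 nM
Compound 3 `O=C(CCl)NC(=O)Nc1cccc(OC2CCCCCC2)c1` gives 7200 nM

Compound 3 at 7200 nM cannot be separated from the other two compounds, and no order among the three can be drawn. Its comparisons are a 1.1-fold higher number from compound 2 to compound 3 (0.06 log units; within the scatter) and a 1.2-fold higher number from compound 1 to compound 3 (0.06 log units; within the scatter) in this assay. The remaining step is a 1.0-fold higher number from compound 1 to compound 2 (0.01 log units; within the scatter) and it is equally small.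

The next change gives compound 4 `O=C(CCl)NC(=O)Nc1cccc(Oc2ccccc2)c1` with phenyl in place of cycloheptyl on an oxygen on an aromatic ring. Among the measured compounds shown here, all three measured steps change the group at this same place, so they are the only evidence that bears on it. None of them replaces a non-aromatic ring with an aromatic one, so they guide the estimate only indirectly, and the range is kept wide.

With no measured step beyond the scatter at this place, the expectation starts from compound 3 at 7200 nM and no clear shift in this assay is expected. The estimated change is a 1.1-fold lower number from compound 3 to compound 4 (0.04 log units; within the scatter) and is expected to stay within the scatter. For compound 4 the estimated value is 6500 nM with an expected range from 3000 nM to 14000 nM.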

Compound 4, concentration for 50% growth inhibition: 8100 nM
For compound 4 the middle estimate is 1.2-fold (0.10 log units) below the measured one; low and high end bracket the measured number.
By their numbers in this assay, from the lowest: compounds 1, 2, 3 and 4 (each within the scatter of the next).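

In this assay, among the compounds shown here, phenyl is the first aromatic ring on this oxygen, and it gives a 1.1-fold higher number from compound 3 to compound 4 (0.05 log units; within the scatter), while the comparisons with the smaller non-aromatic rings give a 1.3-fold higher number from compound 2 to compound 4 (0.11 log units; within the scatter) and a 1.3-fold higher number from compound 1 to compound 4 (0.12 log units; within the scatter). Swapping a non-aromatic ring for an aromatic one therefore does not separate compound 4 from any of compounds 1, 2 and 3, so the flat picture seen among the three non-aromatic rings extends to this change, and no order can be drawn among the four compounds. No supporting measurement is available to explain why the read-out stays flat at this place.

Going by these compounds, all four compounds carry a carbon-only ring on this oxygen, so it remains open whether a longer chain there, or an amine or a carboxylic acid on the phenyl ring, would move the number beyond the scatter. The rest of the molecule is the same in all four compounds, so these values say nothing about how much the shared core contributes to growth inhibition.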